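Shortening the link to the chloroaryl group in compound 1

This account rests on a few compounds, and the source may have more. Where it says the series, first, only, none or still open, it means among the compounds named here.

Compound 1 `COc1cc(CC(C)C(=O)N2CCN(c3ccc(C(F)(F)F)cc3[C@@H](N)CC(C)C)CC2)ccc1Cl` was tested in an assay on HEK293 cells for displacement of a labelled ligand from Melanocortin receptor 4 (Homo sapiens) (on this read-out higher numbers stand for weaker inhibition and lower numbers for stronger inhibition), where compound 1 gives 230 nM. Compound 2 `CC(C)C[C@H](N)c1cc(F)ccc1N1CCN(C(=O)C(C)Cc2ccc(Cl)cc2)CC1` gives 390 nM in this assay, and the two values lie within the usual scatter of each other. Compound 3 `CC(C)C[C@H](N)c1cc(C(F)(F)F)ccc1N1CCN(C(=O)COc2ccc(Cl)cc2)CC1` has not been measured. It differs from compound 1 by (4-chlorophenoxy)methyl in place of 1-(4-chloro-3-methoxybenzyl)ethyl on a carbonyl carbon. Going by the values given here, no measured pair shows this kind of change, so only a modest step, probably toward a weaker result, is expected. Compound 3 is expected to give about 450 nM, in a range from 150 nM to 1400 nM. This expectation means a step of a 2.0-fold higher number from compound 1 to compound 3 (0.29 log units; within the scatter).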

Compound 3, inhibition constant: 2900 nM
For compound 3 the middle estimate is 6.4-fold (0.81 log units) below the measured one; the whole stated range lies below it.
By their numbers in this assay, from the lowest: compounds 1 and 2 (each within the scatter of the next); then compound 3.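

In this assay, (4-chlorophenoxy)methyl in place of 1-(4-chloro-3-methoxybenzyl)ethyl on this carbonyl carbon gives a 13-fold higher number from compound 1 to compound 3 (1.10 log units; beyond the scatter), so this position does not accept every group that carries a chloroaryl ring equally. Both groups have one aromatic ring, one chlorine and one hydrogen-bond acceptor, so these shared counts alone do not preserve the value. Nothing measured here explains the step. On these data alone, the two groups differ in more than one feature, and which difference matters remains open. A (4-chloro-3-methoxyphenoxy)methyl group would show whether the methoxy group can restore the value with the oxygen link in place.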